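The source may hold more compounds than are shown below. What is called first, only, known or untested is meant among the compounds shown, and "the series" means these compounds.

Measured compounds:
- compound 1, `CCCCCCCCNc1nc(SCc2ccc(C(F)(F)F)cc2)nc2ccccc12`, 13400 nM
- compound 2, `COc1ccc(Nc2nc(SCc3ccc(C(F)(F)F)cc3)nc3ccccc23)cc1`, 23500 nM
- compound 3, `COc1ccc(Nc2nc(SCc3ccc(C(F)(F)F)cc3)nc3ccccc23)cc1OC`, 17900 nM

All three were tested in a functional assay on HGC-27 cells (Homo sapiens) for cytotoxicity, read by MTT assay, with a stated time of 72 h; on this read-out lower numbers stand for stronger inhibition and higher numbers for weaker inhibition. Compound 1 gives the lowest of the three numbers, but its nearest neighbour, compound 3, and its furthest, compound 2, both sit within the scatter of it, so no ranking among them can be claimed.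

The unmeasured compound 4, `Fc1ccc(Nc2nc(SCc3ccc(C(F)(F)F)cc3)nc3ccccc23)cc1Cl`, is reached from compound 1 by the change (3-chloro-4-fluorophenyl in place of octyl on a nitrogen on an aromatic ring). Two of the measured steps bear on this: a 1.8-fold higher number from compound 1 to compound 2 (0.24 log units; within the scatter) and a 1.3-fold higher number from compound 1 to compound 3 (0.13 log units; within the scatter). Both swap the octyl chain on the aromatic nitrogen for a substituted phenyl group, and both move the number only within the scatter. The step of a 1.3-fold lower number from compound 2 to compound 3 (0.12 log units; within the scatter) shows that changing the substituents on that phenyl group also stayed within the scatter. For the measured compounds named here, no measured pair carries a halogen on this phenyl group, so the data give no direct guide for chloro and fluoro substituents.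

Compound 4 is therefore expected to behave much like compounds 2 and 3, with a step of a 1.3-fold higher number from compound 1 to compound 4 (0.10 log units; within the scatter) that does not go beyond the scatter. The estimate for compound 4 in this assay is 17000 nM, with a range from 8000 nM to 36000 nM.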

Compound 4, half-maximal inhibitory concentration: 14700 nM
Estimate against measurement, compound 4: 1.2-fold (0.06 log units) above, within the range that was stated.
By their numbers in this assay, from the lowest: compounds 1, 4, 3 and 2 (each within the scatter of the next).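

In this assay, the 3-chloro-4-fluorophenyl group brings the first halogens seen on this nitrogen, and putting it in place of the octyl chain gives a 1.1-fold higher number from compound 1 to compound 4 (0.04 log units; within the scatter) as its result, so a flexible chain without a ring and a halogen-bearing aromatic ring of the same heavy-atom count read alike here. Setting it against the two methoxy-bearing phenyl groups gives a 1.2-fold lower number from compound 3 to compound 4 (0.09 log units; within the scatter) in one comparison and a 1.6-fold lower number from compound 2 to compound 4 (0.20 log units; within the scatter) in the other, which extends the earlier picture: with chlorine and fluorine in place of methoxy groups on that phenyl ring, all four compounds remain within the scatter of one another. Nothing at hand explains this flat result, and the compounds alone cannot supply an explanation.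

The compounds shown leave open whether any group on this nitrogen can move the number beyond the scatter, such as a short ethyl chain, a chain ending in an amine, or a phenyl ring carrying a carboxylic acid. They also leave open whether changes elsewhere on the shared core matter more than changes at this nitrogen.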